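Fluoro to methoxy on the N-aryl ring

The source may report more compounds than this note shows. Statements on the series, on what has been measured and on what is new or still open speak of the compounds shown alone.

Two compounds of the series have numbers in a functional assay on HT-29 cells (Homo sapiens) for antiproliferative activity, read by MTT assay, with a stated time of 72 h (on this read-out lower numbers stand for stronger inhibition and higher numbers for weaker inhibition), so far. Compound 1 `COc1ccc(-n2c(=O)c(C(=O)Nc3ccc(Oc4ccnc5c4ccn5C)cc3)cc3cccnc32)cc1` gives 2050 nM in this assay. Going by the values given here, compound 2 `Cn1ccc2c(Oc3ccc(NC(=O)c4cc5cccnc5n(-c5ccc(F)cc5)c4=O)cc3F)ccnc21` gives 160 nM in this assay, the lowest of the two numbers, and the gap to compound 1 lies beyond the scatter; the two structures differ in more than one place, so no single step is drawn between them.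

Compound 3 `COc1ccc(-n2c(=O)c(C(=O)Nc3ccc(Oc4ccnc5c4ccn5C)c(F)c3)cc3cccnc32)cc1` has not been measured in this assay. It differs from compound 2 in one place: methoxy in place of fluoro on an aromatic carbon, para to a large group; cut one bond further out, 4-fluorophenyl becomes 4-methoxyphenyl. Among the compounds with values here, no measured pair isolates this change. Compound 1 carries the methoxy and sits much higher than compound 2, but it also lacks the fluoro on the anilide ring, so the two differences cannot be separated.

The expectation is a step from compound 2 to compound 3 of a 3.4-fold higher number from compound 2 to compound 3 (0.54 log units; beyond the scatter), towards a weaker value. For compound 3 the estimate is 550 nM, with a range from 160 nM to 1900 nM.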

Compound 3, half-maximal inhibitory concentration: 1290 nM
For compound 3 the middle estimate is 2.3-fold (0.37 log units) below the measured one; the measured number falls inside the stated range.
By their numbers in this assay, from the lowest: compound 2; then compounds 3 and 1 (each within the scatter of the next).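

In this assay, the change from 4-fluorophenyl to 4-methoxyphenyl now stands alone, with everything else in the structure held fixed: the step is an 8.1-fold higher number from compound 2 to compound 3 (0.91 log units; beyond the scatter), beyond the scatter, so this position para to a large group does respond to what it carries. With the methoxy in place, fluoro in place of hydrogen on an aromatic carbon gives a 1.6-fold lower number from compound 1 to compound 3 (0.20 log units; within the scatter), within the scatter, so that second change shows no readable effect on this background, and of the two differences between compound 1 and compound 2, only the methoxy for fluoro change has a step beyond the scatter. Nothing measured on these compounds accounts for the size of the methoxy step.

Open, as far as these compounds go, is whether fluoro in place of hydrogen would also stay within the scatter on the 4-fluorophenyl background, since this single step comes from the 4-methoxyphenyl compounds alone. Also open, from the compounds shown here alone, is how this position tolerates other groups, such as a chloro, a hydroxyl, an ethoxy or a dimethylamino group, and so whether the step belongs to methoxy specifically or to any replacement of fluoro.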